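This account rests on a few compounds, and the source may have more. Where it says the series, first, only, none or still open, it means among the compounds named here.

Compound 1 `CC/C=C\C/C=C\C/C=C\CCCCCCCC1(O)CC(=O)c2c(O)cc(OCOC)cc2O1` is one of two measured members of the series, and in a functional assay on MDA-MB-231 cells (Homo sapiens) for antiproliferative activity, read by MTT assay (a higher number here means a weaker inhibitor, a lower number a stronger inhibitor), compound 1 gives 6790 nM. Within the data shown here, its only neighbour is compound 2 `CC/C=C\C/C=C\C/C=C\CCCCCCCC1(O)CC(=O)c2c(O)cc(O)cc2O1`, which in this assay gives 6790 nM; the step of no change at the digits printed from compound 1 to compound 2 (within the scatter) sits at an oxygen on the aromatic ring. On the numbers shown compound 1 stands level with compound 2 within the scatter, so nothing separates the two.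

The next compound, compound 3 `CCCCCCCCCCCCCCCC1(O)CC(=O)c2c(O)cc(OCOC)cc2O1`, departs from compound 1 at the saturated chain: a group of 8 heavy atoms (8 carbon; no ring) in place of a group of 10 heavy atoms (10 carbon; no ring), on a saturated chain carbon, seven bonds along the chain from a saturated ring carbon. Among the measured compounds shown here, no measured step touches the chain; the single known step, hydrogen in place of methoxymethyl on the aromatic oxygen, was flat and gives no lead on a change at the chain end. It is therefore expected that the step from compound 1 to compound 3 in this assay is a 1.0-fold higher number from compound 1 to compound 3 (0.01 log units; within the scatter), with no direction favoured and a wide range to reflect the lack of a comparable step. Compound 3 is estimated at 7000 nM, between 2500 nM and 20000 nM.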

Compound 3, half-maximal inhibitory concentration: > 87000 nM
Compound 3: no number, only a limit (the forecaster's own chance of this, stated with the estimate: 10%); middle value at least 12-fold (1.09 log units) from the limit.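

In this assay, among these compounds, the chain end is the first place where a change shows up in the read-out: the step at the aromatic oxygen gave no change at the digits printed from compound 1 to compound 2 (within the scatter), whereas octyl in place of the group of 10 heavy atoms gives an at least 12-fold higher number from compound 1 to compound 3 (1.10 log units; beyond the scatter). Among the compounds shown here, compound 3 gives > 87000 nM, which is a limit of the assay and not a number, so the full size of this step stays unknown: the limit of > 87000 nM in this assay, at which 1 of the 3 values shown sits. The one change takes away the 3 double bonds and also goes from 10 heavy atoms to 8 in the group, so this position is sensitive, but the step reads both differences as one.

Which of the two differences carries the loss stays open; a saturated decyl group on the same chain carbon would separate them, and a longer chain or a terminal amine would show how much else this position tolerates. Also open, as far as these compounds go, is whether the flat step at the aromatic oxygen would hold with octyl on the chain.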